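A few compounds are considered here, and "the series" means these few. Any claim that something is new, unique, unknown or untested is made for them only; others in the source may bear on it.

Measured so far in a functional assay on L1210 cells (Mus musculus) for antiproliferative activity, with a stated time of 48 h; on this read-out higher numbers stand for weaker inhibition and lower numbers for stronger inhibition:

compound 1, `C=C(Br)C(=O)Nc1ccc(/C=C/C(=O)c2ccccc2)cc1`: 5000 nM
compound 2, `C=C(Br)C(=O)Nc1ccc(/C=C/C(=O)c2ccc(OC)cc2)cc1`: 980 nM
compound 3, `Nc1ccc(/C=C/C(=O)c2ccccc2)cc1`: 88000 nM

Compound 1 and compound 2 share one core and differ in one place, (methoxy in place of hydrogen on an aromatic carbon); in this assay that change gives a 5.1-fold lower number from compound 1 to compound 2 (0.71 log units; beyond the scatter). Compound 3 carries a different core: against compound 1 the difference is hydrogen in place of (1-bromoethenyl)carbonyl on a nitrogen on an aromatic ring, and the step is an 18-fold higher number from compound 1 to compound 3 (1.25 log units; beyond the scatter). Compound 3 therefore shows the highest number of the three; compound 2 gives the lowest, and both of its steps to the others lie beyond the scatter.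

Compound 4, `COc1cccc(C(=O)/C=C/c2ccc(N)cc2)c1`, has not yet been measured in this assay. It stands to compound 3 as compound 2 stands to compound 1: methoxy in place of hydrogen on an aromatic carbon. The two differences are of the same kind but not the same, for the entering group sits para to a large group in compound 2 and meta to a large group in compound 4. One pair, with the group at a different place on the ring, is a thin basis for carrying the step over to the second core.

Among the measured compounds shown here, for compound 4 the step from compound 3 is estimated as a 2.2-fold lower number from compound 3 to compound 4 (0.34 log units; beyond the scatter), a smaller step than the one seen from compound 1 to compound 2, because of the changed place of the entering group relative to the pair a 5.1-fold lower number from compound 1 to compound 2 (0.71 log units; beyond the scatter). Compound 4 is therefore estimated at 40000 nM in this assay, expected to fall between 15000 nM and 110000 nM.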

Compound 4, half-maximal inhibitory concentration: 38000 nM
Compound 4: middle estimate off by 1.1-fold (0.02 log units), on the high side, within the range that was stated.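

In this assay, methoxy in place of hydrogen on an aromatic carbon gives a 2.3-fold lower number from compound 3 to compound 4 (0.36 log units; beyond the scatter) and so runs the same way on both cores, with the two steps not separated in size: the same change on two cores in this assay, a 5.1-fold lower number (0.71 log units; beyond the scatter) from compound 1 to compound 2 and a 2.3-fold lower number (0.36 log units; beyond the scatter) from compound 3 to compound 4, 2.2-fold (0.34 log units) apart, within the scatter of two such steps

This supports carrying the change from the core of compound 1 to the core of compound 3 as a lowering of the number, with the earlier step as a fair guide to its size. Among the compounds shown here, it rests on only two pairs, however, and the methoxy stands meta to a large group in compound 4 but at another place on the ring in compound 2, so the influence of the core cannot be told apart from that of the place. The pairs also give no reason for the lowering and say nothing about cores beyond these two.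

Still open, from the compounds shown here alone, is whether a methoxy at one and the same place on both cores gives matching steps, and whether a chlorine, a hydroxyl or a longer alkoxy chain follows the methoxy on either core. Also open, going by these compounds, is whether an acetyl or a chloroacetyl on the nitrogen would go with a step of the size of an 18-fold higher number from compound 1 to compound 3 (1.25 log units; beyond the scatter) or a smaller one.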